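The source may report more compounds than this note shows. Statements on the series, on what has been measured and on what is new or still open speak of the compounds shown alone.

Measured so far:
compound 1 `N#CC1=C(N)N(c2ccc(S(N)(=O)=O)cc2)C2=C(C(=O)CCC2)C1c1ccccc1` with 10%
compound 2 `N#CC1=C(N)N(c2ccc(S(N)(=O)=O)cc2)C2=C(C(=O)CCC2)C1/C=C/c1ccccc1` with 2%

In a functional assay on Ehrlich cells (Mus musculus) for antiproliferative activity, read by trypan blue exclusion, with a stated time of 2 h, tested at 10 ug/mL (on this read-out higher numbers stand for a stronger effect at the one concentration tested and lower numbers for a weaker effect), compound 2 gives 2%, and its step from compound 1, a number 8 percentage points lower from compound 1 to compound 2 (within the scatter), keeps both within the usual scatter. Compound 3 `COc1cc(CC2C(C#N)=C(N)N(c3ccc(S(N)(=O)=O)cc3)C3=C2C(=O)CCC3)ccc1O` differs from compound 2 by 4-hydroxy-3-methoxybenzyl in place of 2-phenylethenyl on a saturated ring carbon, a change at the same saturated ring carbon. Among the compounds with values here, the only step at that carbon, a number 8 percentage points lower from compound 1 to compound 2 (within the scatter), was within the scatter, so no step beyond the scatter is expected here either, a number 4 percentage points higher from compound 2 to compound 3 (within the scatter). Compound 3 is estimated at 6%, between 0% and 20%.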

Compound 3, a percentage reported as activity, at one concentration (the size of the read-out at that concentration, not a potency): 0%
For compound 3 the middle estimate is 6 percentage points above the measured one, within the range that was stated.
By their numbers in this assay, from the lowest: compounds 3, 2 and 1 (each within the scatter of the next).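

In this assay, 4-hydroxy-3-methoxybenzyl in place of 2-phenylethenyl on the saturated ring carbon gives a number 2 percentage points lower from compound 2 to compound 3 (within the scatter), and in place of phenyl it gives a number 10 percentage points lower from compound 1 to compound 3 (within the scatter). At this position, then, a group that brings oxygen atoms and a hydrogen-bond donor, which 2-phenylethenyl lacks, leaves all three compounds within the scatter of one another. No supporting data bear on this result. On these data alone, whether an amine or a carboxylic acid at this carbon would move the number beyond the scatter remains open. So does how these compounds behave at other concentrations.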